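The compounds below may be only part of what the source reports. "The series", "measured", "known", "first", "only" and "open" are said of these compounds alone.

Measured compounds:
compound 1 `N#CC1=C(N)Oc2c(c3nc4ccccc4nc3c3ccccc23)C12C(=O)N(Cc1cnnn1-c1ccc(F)cc1)c1ccccc12` — in a functional assay on A549 cells (Homo sapiens) for antiproliferative activity, read by MTT assay, with a stated time of 48 h (a higher number here means a weaker inhibitor, a lower number a stronger inhibitor), compound 1 gives > 50000 nM, a limit of the assay
compound 2 `Cc1ccc(-n2nncc2CN2C(=O)C3(C(C#N)=C(N)Oc4c3c3nc5ccccc5nc3c3ccccc43)c3ccccc32)cc1C` — in this assay compound 2 gives > 50000 nM, likewise a limit of the assay

Compound 2 thus stands at the upper limit of this assay, with no number behind it. Within the data shown here, the one measured step, a step that the two limits leave unreadable from compound 1 to compound 2, cannot be read, as both ends sit at the limit (the limit of > 50000 nM in this assay, at which 2 of the 2 values shown sit); it says only that neither the 4-fluorophenyl nor the 3,4-dimethylphenyl compound shows measurable inhibition in this test.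

Compound 3 `N#CC1=C(N)Oc2c(c3nc4ccccc4nc3c3ccccc23)C12C(=O)N(Cc1cnnn1-c1ccc(Cl)c(Cl)c1)c1ccccc12` is not yet measured. It differs from compound 2 by 3,4-dichlorophenyl in place of 3,4-dimethylphenyl on an aromatic nitrogen. Among the measured compounds shown here, no measured step speaks to a dichlorophenyl group, and the step that replaced the aryl group on the same nitrogen gave nothing readable. There is therefore no basis to expect a move out of the range in which compounds 1 and 2 sit. Compound 3 is expected to give a limit again, with an estimated value of 80000 nM (range 20000 nM to 300000 nM), so that the estimated step that the limit leaves unreadable from compound 2 to compound 3 is none beyond the scatter.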

Compound 3, half-maximal inhibitory concentration: > 50000 nM
Compound 3: no number, only a limit; the forecaster's own chance of this, stated with the estimate: 85%; the middle value does not contradict the limit.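

In this assay compound 3 gives > 50000 nM, a limit of the assay, so the steps to compound 3 from compound 1 and compound 2 cannot be read: the limit of > 50000 nM in this assay, at which 3 of the 3 values shown sit.

The compounds shown leave open whether the 4-fluorophenyl, 3,4-dimethylphenyl and 3,4-dichlorophenyl groups differ at all in this assay, and which change would give a measurable value.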